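This account rests on a few compounds, and the source may have more. Where it says the series, first, only, none or still open, it means among the compounds named here.

Compound 1: `COc1ccc(Oc2ncnc3[nH]ccc23)cc1` — in an assay on HEK293-TREx cells for antagonist activity at transient receptor potential cation channel subfamily A member 1 (Homo sapiens), read by fluorescence and calcium flux, with a stated time of 72 h (a lower number here means a stronger inhibitor, a higher number a weaker inhibitor), compound 1 gives a limit of > 32000 nM.
Compound 2: `Fc1cccc(Oc2ncnc3[nH]ccc23)c1F` — in this assay compound 2 gives 2700 nM.
Compound 3: `Fc1ccccc1Oc1ncnc2[nH]ccc12` — in this assay compound 3 gives a limit of > 32000 nM.

Within the data shown here, compound 2 stands alone in this assay as the only measured number; the other two values are limits. The change from compound 2 to compound 4, `Fc1cccc(Oc2ncnc3[nH]ccc23)c1`, is hydrogen in place of fluoro on an aromatic carbon. Among the measured compounds shown here, one measured step bears on it: an at least 11-fold higher number from compound 2 to compound 3 (1.07 log units; beyond the scatter), which also took one fluoro away from the same ring of compound 2 and left only a limit for compound 3, as the limit of > 32000 nM in this assay, at which 2 of the 3 values shown sit, records. The step to compound 4 removes the other fluoro of compound 2, so the measured step is a neighbour of the change rather than the same change, and nothing measured tells how a single fluoro in the position that remains in compound 4 fares. Given that the one known removal of a fluoro from compound 2 ended at a limit, the expected step from compound 2 to compound 4 is a weakening, a 5.6-fold higher number from compound 2 to compound 4 (0.74 log units; beyond the scatter), with wide uncertainty. Compound 4 is therefore estimated at 15000 nM, ranging from 3000 nM to 60000 nM, and a fair chance remains that only a limit is returned.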

Compound 4, half-maximal inhibitory concentration: > 32000 nM
Compound 4 gave a limit, no number; the forecaster's own chance of this, stated with the estimate: 50%; middle value at least 2.1-fold (0.32 log units) away from the limit.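

In this assay, taking away the remaining fluoro also costs the measured number, giving an at least 11-fold higher number from compound 2 to compound 4 (1.07 log units; beyond the scatter), the same printed size as the earlier step, an at least 11-fold higher number from compound 2 to compound 3 (1.07 log units; beyond the scatter). Compound 4 gives only a limit, > 32000 nM. Removing either fluoro therefore has the same printed outcome, and among the compounds shown a measured number appears only with both fluoro groups present, in compound 2, while the others sit at one limit: the limit of > 32000 nM in this assay, at which 3 of the 4 values shown sit.

The compounds shown leave open how far compound 3 and compound 4 lie past that limit, and so whether the two single fluoro groups differ from each other. Also open, going by these compounds, is whether a chloro, methyl or nitrile group in place of either fluoro would keep a measured number in this assay.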